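The source may report more compounds than this note shows. Statements on the series, on what has been measured and on what is new or still open speak of the compounds shown alone.

Compound 1 `[N-]=[N+]=N[C@@H]1C(n2ccc(=O)[nH]c2=O)[Se][C@H](CO)[C@H]1O` and compound 2 `[N-]=[N+]=N[C@@H]1C(n2cc(Br)c(=O)[nH]c2=O)[Se][C@H](CO)[C@H]1O` share one core. In a functional assay on A549 cells (Homo sapiens) for cytotoxicity, read by sulforhodamine B assay (on this read-out higher numbers stand for weaker inhibition and lower numbers for stronger inhibition), compound 1 gives > 100000 nM, which is a limit of the assay. Compound 2 in this assay gives > 100000 nM, likewise a limit. The step that the two limits leave unreadable from compound 1 to compound 2 therefore cannot be read, because both values sit at the limit of > 100000 nM in this assay, at which 2 of the 2 values shown sit. Compound 3 `[N-]=[N+]=N[C@@H]1C(n2cc(I)c(=O)[nH]c2=O)[Se][C@H](CO)[C@H]1O` differs from compound 2 by iodo in place of bromo on an aromatic carbon. With both measured values at the limit, nothing shows whether one halogen or the other shifts the read-out, so compound 3 is expected to stay at the limit too. The value estimated for compound 3 is 200000 nM, with a range from 80000 nM to 600000 nM. The expected step is a step that the limit leaves unreadable from compound 2 to compound 3.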

Compound 3, half-maximal inhibitory concentration: > 100000 nM
Compound 3: a limit, no number; the forecaster's own chance of this, stated with the estimate: 85%; the middle value does not contradict the limit.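

For the compounds shown here, no step among compound 1, compound 2 and compound 3 can be read, because each value is only a limit: the limit of > 100000 nM in this assay, at which 3 of the 3 values shown sit. The compounds shown leave open whether hydrogen, bromo or iodo on that aromatic carbon makes any difference in this assay.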